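Amide nitrogen swap on the hydroxy analogue

A few compounds are considered here, and "the series" means these few. Any claim that something is new, unique, unknown or untested is made for them only; others in the source may bear on it.

Among the measured compounds shown here, compound 3 `CCn1c(C(=O)NCCCN(C)C)ccc1C(CC)(CC)c1ccc(OCC(O)C(C)(C)C)c(C)c1` stands lowest of the three numbers measured so far in an assay on HL-60 cells for agonist activity at vitamin D3 receptor (Homo sapiens), read by microscopy, with a stated time of 96 h; a higher number here means that more compound is needed for the effect, a lower number that less compound is needed: compound 3 gives 37 nM. Compound 1 `CCn1c(C(=O)NCCCN(C)C)ccc1C(CC)(CC)c1ccc(OCC(=O)C(C)(C)C)c(C)c1` gives 96 nM, and the hydroxyl-for-carbonyl change gave a 2.6-fold lower number from compound 1 to compound 3 (0.41 log units; beyond the scatter). Compound 2 `CCn1c(C(=O)N(CCC#N)CCC#N)ccc1C(CC)(CC)c1ccc(OCC(=O)C(C)(C)C)c(C)c1` gives 870 nM, the highest number in the set.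

Compound 4 `CCn1c(C(=O)Nc2cccc(C(F)(F)F)c2)ccc1C(CC)(CC)c1ccc(OCC(O)C(C)(C)C)c(C)c1` is to be measured in this assay. It differs from compound 3 on the amide nitrogen: 3-(trifluoromethyl)phenyl in place of 3-(dimethylamino)propyl on an amide-type nitrogen. For the measured compounds named here, the only measured step touching that position is a 9.1-fold higher number from compound 1 to compound 2 (0.96 log units; beyond the scatter), where the dimethylaminopropyl group was also lost. The entering group in compound 4 is a ring rather than a chain, so that step is only a loose guide, but it points toward a higher number. Going by the values given here, a modest rise beyond the scatter is therefore expected, smaller than the one seen between compound 1 and compound 2, giving an expected 4.1-fold higher number from compound 3 to compound 4 (0.61 log units; beyond the scatter). For compound 4 the estimated value in this assay is 150 nM, with a range from 40 nM to 600 nM.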

Compound 4, half-maximal effective concentration: > 50000 nM
Compound 4 ended at the assay's limit; the forecaster's own chance of this, stated with the estimate: 5%; middle value at least 330-fold (2.52 log units) away from the limit.
By their numbers in this assay, from the lowest: compound 3; then compound 1; then compound 2. At a limit, above all of these: compound 4.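

Replacing 3-(dimethylamino)propyl with 3-(trifluoromethyl)phenyl on the amide-type nitrogen gives an at least 1300-fold higher number from compound 3 to compound 4 (3.13 log units; beyond the scatter) in this assay, a far larger step than a 9.1-fold higher number from compound 1 to compound 2 (0.96 log units; beyond the scatter), so this position is much less forgiving than the earlier pair suggested. The reading for compound 4 is a limit of the assay and not a number: the limit of > 50000 nM in this assay, at which 1 of the 4 values shown sits. Against this, the hydroxyl-for-carbonyl change, a 2.6-fold lower number from compound 1 to compound 3 (0.41 log units; beyond the scatter), is small, and the hydroxyl side chain shared by compound 3 and compound 4 does not keep the number low once the amide nitrogen group changes.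

Loss of the dimethylamino group and entry of the aromatic ring occur together in compound 4, and the compounds shown cannot separate them. Open, on these data alone, is where an unsubstituted phenyl, or a propyl chain ending in a carboxylic acid, would fall on this nitrogen.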